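The compounds below may be only part of what the source reports. "The series", "measured", "known", "first", "only" and "open" are said of these compounds alone.

In a functional assay on PC-3 cells (Homo sapiens) for cytotoxicity, read by sulforhodamine B assay, with a stated time of 72 h (on this read-out higher numbers stand for weaker inhibition and lower numbers for stronger inhibition), compound 1 `COc1cc(/C=C/C(O)=C/C(=O)/C=C/c2ccc(OC)c(OC)c2)ccc1O` gives 33100 nM. Compound 3 `COc1cc(/C=C/C(=O)/C=C(O)/C=C/c2ccc(OC(C)(C)C(=O)Nc3ccc(C#N)c(C(F)(F)F)c3)c(OC)c2)ccc1O` gives 48100 nM, and these two numbers lie within the usual scatter of each other. Within the data shown here, they are the only exact numbers so far. Compound 2 `COc1cc(/C=C/C(=O)/C=C(O)/C=C/c2ccc(OC(C)(C)C(=O)Nc3ccc([N+](=O)[O-])c(C(F)(F)F)c3)c(OC)c2)ccc1O` reads > 100000 nM, which is a limit of the assay and not a number.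

Compound 4 `COc1cc(/C=C/C(=O)/C=C(O)/C=C/c2ccc(OC(C)(C)C(=O)Nc3ccc(Cl)c(C(F)(F)F)c3)c(OC)c2)ccc1O` departs from compound 3 at one place: chloro in place of cyano on an aromatic carbon. This puts chloro in place of cyano on an aromatic carbon, ortho to a trifluoromethyl group. Among the measured compounds shown here, the one measured step at this same place is an at least 2.0-fold lower number from compound 2 to compound 3 (0.31 log units; beyond the scatter), with cyano in place of nitro. For the measured compounds named here, that step shows the number can respond to a change here, but its true size is unknown since one end is a limit, and no chloro compound has been measured. No clear direction can be drawn from it, so no shift beyond the scatter is expected. The estimated step is a 1.2-fold lower number from compound 3 to compound 4 (0.08 log units; within the scatter). Compound 4 is expected at about 40000 nM, with an estimated range of 15000 nM to 100000 nM.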

Compound 4, half-maximal inhibitory concentration: > 100000 nM
Compound 4 was reported as a limit; the forecaster's own chance of this, stated with the estimate: 15%; at least 2.5-fold (0.39 log units) between middle value and limit.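

In this assay, replacing cyano with chloro gives an at least 2.0-fold higher number from compound 3 to compound 4 (0.31 log units; beyond the scatter), so this position on the ring responds to a second change as well as to the earlier at least 2.0-fold lower number from compound 2 to compound 3 (0.31 log units; beyond the scatter). Of the three groups shown here, only the cyano group of compound 3 gives an exact number, so both changes away from cyano lead to weaker inhibition. Compound 2 and compound 4 each read as a limit of the assay and not as a number, and the step between them cannot be read, because both stop at the same limit: the limit of > 100000 nM in this assay, at which 2 of the 4 values shown sit.

From the compounds shown here alone, it remains open what an amine, a methoxy group or a plain hydrogen at this position would give, and whether any group here can bring the number clearly below compound 3 at 48100 nM. Going by these compounds, the trifluoromethyl group is the same in compound 2, compound 3 and compound 4, so its own contribution also remains open.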